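Adding a Third Methoxy Group: From Compound 3 to Compound 4

The compounds below may be only part of what the source reports. "The series", "measured", "known", "first", "only" and "open" are said of these compounds alone.

Compound 1, `Cc1cc(O)c(C2=NN(c3ccc(S(N)(=O)=O)cc3)C(c3ccccc3O)C2)cc1Cl`: in a functional assay on SNB-75 cells (Homo sapiens) for antiproliferative activity, with a stated time of 48 h (on this read-out lower numbers stand for stronger inhibition of growth and higher numbers for weaker inhibition of growth), compound 1 gives 1790 nM.
Compound 2, `Cc1cc(O)c(C2=NN(c3ccc(S(N)(=O)=O)cc3)C(c3ccccc3Cl)C2)cc1Cl`: compound 2 gives 2230 nM.
Compound 3, `COc1ccc(C2CC(c3cc(Cl)c(C)cc3O)=NN2c2ccc(S(N)(=O)=O)cc2)cc1OC`: compound 3 gives 2700 nM.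

Compound 3 shows the highest number of the three, yet each gap to the other two lies within the scatter, so the three cannot be told apart on this read-out. Compound 4, `COc1ccc(C2CC(c3cc(Cl)c(C)cc3O)=NN2c2ccc(S(N)(=O)=O)cc2)c(OC)c1OC`, differs from compound 3 by methoxy in place of hydrogen on an aromatic carbon. The measured steps that bear on this change are those that swapped the group on the same saturated ring carbon: a 1.5-fold higher number from compound 1 to compound 3 (0.18 log units; within the scatter) and a 1.2-fold higher number from compound 2 to compound 3 (0.08 log units; within the scatter), both within the scatter. Nothing here points to a step beyond the scatter in either direction. The expected step is a 1.1-fold higher number from compound 3 to compound 4 (0.05 log units; within the scatter), and compound 4 is estimated at 3000 nM, with a range from 1500 nM to 6000 nM.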

Compound 4, concentration for 50% growth inhibition: 2450 nM
Compound 4: middle estimate off by 1.2-fold (0.09 log units), on the high side, within the range that was stated.
By their numbers in this assay, from the lowest: compounds 1, 2, 4 and 3 (each within the scatter of the next).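

In this assay, going from 3,4-dimethoxyphenyl to 2,3,4-trimethoxyphenyl gives a 1.1-fold lower number from compound 3 to compound 4 (0.04 log units; within the scatter), so a methoxy group on this aromatic carbon, ortho to a large group, brings no change that can be told from the scatter. The other two steps, a 1.1-fold higher number from compound 2 to compound 4 (0.04 log units; within the scatter) and a 1.4-fold higher number from compound 1 to compound 4 (0.14 log units; within the scatter), show that all four aromatic groups tried on this saturated ring carbon remain within the scatter of one another. Nothing shown gives a reason for these small steps.

Still open, on these data alone, is whether an amine or a carboxylic acid on this aromatic carbon would produce a step beyond the scatter. The same question stands for a longer chain, such as butoxy, in place of methoxy.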